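A longer chain on compound 2, at the limit

This account rests on a few compounds, and the source may have more. Where it says the series, first, only, none or still open, it means among the compounds named here.

- compound 1 `Cc1c(F)c(N)c2c(=O)cc(-c3ccc(N)c(F)c3)oc2c1F`: > 100000 nM
- compound 2 `CCCCc1c(F)c(N)c2c(=O)cc(-c3ccc(N)c(F)c3)oc2c1F`: > 100000 nM

In a functional assay on HeLa cells (Homo sapiens) for cytotoxicity, read by neutral red uptake, with a stated time of 3 days (a lower number here means a stronger inhibitor, a higher number a weaker inhibitor), compound 1 gives > 100000 nM, which is a limit and not a number. Compound 2 gives > 100000 nM, which is also a limit, so its true position is not known. The evidence so far is the limit of > 100000 nM in this assay, at which 2 of the 2 values shown sit.

Compound 3 `CCCCCCc1c(F)c(N)c2c(=O)cc(-c3ccc(N)c(F)c3)oc2c1F` lengthens the chain of compound 2: ethyl in place of hydrogen on a saturated chain carbon, four bonds along the chain from an aromatic carbon.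

Among the measured compounds shown here, one measured step bears on this change, a step that the two limits leave unreadable from compound 1 to compound 2, where propyl took the place of hydrogen on a saturated chain carbon bound to an aromatic carbon. Given a step that the two limits leave unreadable from compound 1 to compound 2, no step beyond the scatter is expected in this assay, and no direction can be named. The step expected is a number no higher from compound 2 to compound 3 (the limit leaves the size open). Compound 3 is estimated at 100000 nM, with an expected range from 40000 nM to 200000 nM.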

Compound 3, half-maximal inhibitory concentration: 21000 nM
Compound 3: middle estimate off by 4.8-fold (0.68 log units), on the high side, and the stated range ends above it.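

In this assay, among the compounds shown here, ethyl in place of hydrogen on a saturated chain carbon, four bonds along the chain from an aromatic carbon, gives the first step that can be read: an at least 4.7-fold lower number from compound 2 to compound 3 (0.67 log units; beyond the scatter). The whole change in the chain shows an at least 4.7-fold lower number from compound 1 to compound 3 (0.67 log units; beyond the scatter), so a change in this chain can move the number beyond the scatter, which the unreadable step between the two shorter chains could not show. Both steps give only a smallest size, for compound 1 and compound 2 each stand at a limit and not at a number: the limit of > 100000 nM in this assay, at which 2 of the 3 values shown sit.

Going by these compounds, the true size of the step therefore stays open. On these data alone, it is also open whether a longer chain would lower the number further, and whether an amine or a carboxylic acid in place of the ethyl would keep the step.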